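A few compounds are considered here, and "the series" means these few. Any claim that something is new, unique, unknown or untested is made for them only; others in the source may bear on it.

Measured compounds:
- compound 1, `CC(C)=CCn1c(CN2CCN(C(=O)C3CC3)CC2)nc2ccccc21`, in an assay on isolated protein for inhibition of aldehyde dehydrogenase 1A1 (Homo sapiens), read by spectrophotometry, tested at 10 uM (on this read-out higher numbers stand for more inhibition at the one concentration tested (going by the name of the read-out) and lower numbers for less inhibition), gives 74.3%
- compound 2, `Cc1cccc(Cn2c(CN3CCN(C(=O)c4ccc([N+](=O)[O-])cc4)CC3)nc3ccccc32)c1`, in this assay gives 24.3%

Compound 2 stands lowest of the two numbers; its nearest neighbour is compound 1, whose value lies higher by a gap beyond the usual scatter. Among the compounds with values here, compounds 1 and 2 differ in more than one place, so no single step connects them and their two values can only be set side by side.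

Compound 3, `Cc1cccc(Cn2c(CN3CCN(C(=O)c4ccco4)CC3)nc3ccccc32)c1`, is the unmeasured case. It derives from compound 2 by one change on the carbonyl carbon whose other neighbours are the amide-type nitrogen in a ring: furan-2-yl in place of 4-nitrophenyl on a carbonyl carbon. Within the data shown here, nothing among the measured pairs isolates a swap on that carbonyl, so the size of the step is open. The move from a six-membered to a five-membered aromatic ring on this carbonyl is expected to shift the inhibition only modestly, if at all, and the step from compound 2 to compound 3 is estimated as a number 10.7 percentage points higher from compound 2 to compound 3 (beyond the scatter), a rise that may not clear the scatter. For compound 3 in this assay the estimated value is 35%, with a range from 10% to 65%.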

Compound 3, a percentage reported as inhibition, at one concentration (the size of the read-out at that concentration, not a potency): 73.2%
Compound 3: middle estimate off by 38.2 percentage points, on the low side; the whole stated range lies below it.
By their numbers in this assay, from the lowest: compound 2; then compounds 3 and 1 (each within the scatter of the next).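

In this assay, within the data shown here, the group on the carbonyl carbon whose other neighbour is the amide-type nitrogen in a ring proves to be a position of large effect: furan-2-yl in place of 4-nitrophenyl gives a number 48.9 percentage points higher from compound 2 to compound 3 (beyond the scatter), the first step that can be read at a single place. The remainder of the structure shared by this pair therefore does not by itself hold the read-out low, and this one change on the carbonyl is enough to move it well beyond the scatter. Nothing at hand bears on the reason for the step, and the swap alters the ring size, the hetero atom and the presence of the nitro group all at once.

As far as these compounds go, whether the low value of compound 2 belongs to the nitro group or to the six-membered ring itself stays open, and a plain phenyl or a thiophene on the same carbonyl would separate the two. Also open, from the compounds shown here alone, is how this carbonyl position responds to groups outside the aromatic rings, such as a morpholine or a longer alkyl chain.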